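A few compounds are considered here, and "the series" means these few. Any claim that something is new, unique, unknown or untested is made for them only; others in the source may bear on it.

Compound 1 `COc1ccc2nc(-c3ccc(N/C=C\C(=O)c4ccc(OC)c(O)c4)c(C)c3)sc2c1` gives 18000 nM in a functional assay on A549 cells (Homo sapiens) for antiproliferative activity, read by sulforhodamine B assay, with a stated time of 48 h (a lower number here means a stronger inhibitor, a higher number a weaker inhibitor), the highest number among the three measured compounds. Compound 2 `COc1cc(OC)c2sc(-c3ccc(N/C=C\C(=O)c4ccc(OC)c([N+](=O)[O-])c4)c(C)c3)nc2c1` gives 12100 nM in this assay, within the scatter of compound 1, and compound 3 `COc1cc(OC)c2sc(-c3ccc(N/C=C\C(=O)c4ccc(OC)c([N+](=O)[O-])c4)cc3)nc2c1` gives 5800 nM in this assay. The difference between the core of compound 1 and the core of compound 2 is not broken down here. Between compound 2 and compound 3 the change is hydrogen in place of methyl on an aromatic carbon, and it produced a 2.1-fold lower number from compound 2 to compound 3 (0.32 log units; beyond the scatter). Compound 4 `COc1ccc2nc(-c3ccc(N/C=C\C(=O)c4ccc(OC)c(O)c4)cc3)sc2c1` has not yet been measured. From compound 1 it differs by hydrogen in place of methyl on an aromatic carbon, the same change as that made from compound 2 to compound 3, with the same surroundings at the place. Because a 2.1-fold lower number from compound 2 to compound 3 (0.32 log units; beyond the scatter) was seen, a step of similar size is expected here, so that compound 1 at 18000 nM points to compound 4 at about 8500 nM in this assay. The expected range for compound 4 runs from 4000 nM to 18000 nM. The step from compound 1 to compound 4 is thus expected to be a 2.1-fold lower number from compound 1 to compound 4 (0.33 log units; beyond the scatter), resting on a single precedent, so the expectation stays tentative.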

Compound 4, half-maximal inhibitory concentration: 12800 nM
Compound 4: the middle estimate sits 1.5-fold (0.18 log units) below what was measured, within the range that was stated.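

On the second core, hydrogen in place of methyl gives a 1.4-fold lower number from compound 1 to compound 4 (0.15 log units; within the scatter) in this assay. Set beside the earlier step, the two readings cannot be told apart: the same change on two cores in this assay, a 2.1-fold lower number (0.32 log units; beyond the scatter) from compound 2 to compound 3 and a 1.4-fold lower number (0.15 log units; within the scatter) from compound 1 to compound 4, 1.5-fold (0.17 log units) apart, within the scatter of two such steps. So the change carries across these two cores without a detectable difference in size, but the step on the core of compound 1 does not alone establish a gain, and two cores that differ in more than one place say nothing about the wider series.

Only methyl and hydrogen are compared at this place, which leaves open how ethyl, chlorine, methoxy or an amine on the same aromatic carbon would read in this assay. Also open, as far as these compounds go, is how the hydroxyl and nitro groups on the far aromatic ring compare on a single core, since each is paired here with a different set of methoxy groups on the core.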